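The source may hold more compounds than are shown below. What is called first, only, known or untested is meant among the compounds shown, and "the series" means these compounds.

In a functional assay on MDA-MB-435S cells (Homo sapiens) for antiproliferative activity, read by MTT assay, with a stated time of 72 h (a higher number here means a weaker inhibitor, a lower number a stronger inhibitor), three compounds sharing a core have been measured. Compound 3, `O=c1c(Cl)c(CSC(=S)N2CCCC2)oc2ccccc12`, gives 1800 nM. Compound 1, `CC(C)N(C(=S)SCc1oc2ccccc2c(=O)c1Cl)C(C)C`, gives 23600 nM. Within the data shown here, the one change between them, (diisopropylamino in place of pyrrolidin-1-yl on a thiocarbonyl carbon), brings a 13-fold higher number from compound 3 to compound 1 (1.12 log units; beyond the scatter). Compound 2, `Cc1ccc2c(=O)c(CSC(=S)N3CCCC3)coc2c1`, gives 1900 nM in this assay, a number within the scatter of that of compound 3; how the cores of compound 2 and compound 3 differ is not broken down here. Compound 4, `Cc1ccc2c(=O)c(CSC(=S)N(C(C)C)C(C)C)coc2c1`, has not yet been measured. Among the measured compounds shown here, it differs from compound 2 by diisopropylamino in place of pyrrolidin-1-yl on a thiocarbonyl carbon, and the place reads the same word for word for both pairs, so this is the same change as the one from compound 3 to compound 1. For compound 4 the expected step is a 12-fold higher number from compound 2 to compound 4 (1.06 log units; beyond the scatter), close in size to a 13-fold higher number from compound 3 to compound 1 (1.12 log units; beyond the scatter). That expectation rests on a single earlier pair with a different core and on nothing else. On this basis compound 4 is expected to give about 22000 nM in this assay, likely between 8000 nM and 60000 nM.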

Compound 4, half-maximal inhibitory concentration: 240 nM
For compound 4 the middle estimate is 92-fold (1.96 log units) above the measured one, outside the stated range (below it).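

Diisopropylamino in place of pyrrolidin-1-yl on a thiocarbonyl carbon now gives a 7.9-fold lower number from compound 2 to compound 4 (0.90 log units; beyond the scatter), so the step points the opposite way from the earlier one. Set side by side in this assay, the two steps do not agree: the same change on two cores in this assay, a 13-fold higher number (1.12 log units; beyond the scatter) from compound 3 to compound 1 and a 7.9-fold lower number (0.90 log units; beyond the scatter) from compound 2 to compound 4, 100-fold (2.02 log units) apart, beyond the scatter of two such steps. This shows that, in this series, the size and even the direction of this change did not carry from one core to the other, so a single pair on one core is a poor guide to the result on another, but it does not show which difference between the two cores goes with the reversal.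

The compounds shown leave open how other amines on the thiocarbonyl carbon, such as diethylamino or morpholin-4-yl, would behave on each of the two cores. Among these compounds, they also leave open whether a third core would follow the step seen for compound 1 or the one seen for compound 4.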